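Alkylating the Ring Amine of a B1 Antagonist

The source may hold more compounds than are shown below. What is called first, only, known or untested is meant among the compounds shown, and "the series" means these compounds.

Measured compounds:
Compound 1 `Cc1ccc(S(=O)(=O)N2C=CNC(=O)[C@H]2CC(=O)N[C@@H]2CCCc3ccccc32)cc1` gives 3.3 nM in an in vitro functional assay on cells for antagonist activity at B1 bradykinin receptor (Homo sapiens), read by luminescence and calcium flux, with a stated time of 2 h; a higher number here means a weaker inhibitor, a lower number a stronger inhibitor.
Compound 2 `Cc1ccc(S(=O)(=O)N2C=CNC(=O)[C@H]2CC(=O)NC2CCCCC2C)cc1` gives 25.9 nM in this assay.
Compound 3 `Cc1ccc(S(=O)(=O)N2C=CNC(=O)[C@H]2CC(=O)N[C@H]2CCN(C)CC2(C)C)cc1` gives 0.42 nM in this assay.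

Compound 3 stands lowest of the three numbers, with a 7.9-fold lower number from compound 1 to compound 3 (0.90 log units; beyond the scatter) and a 62-fold lower number from compound 2 to compound 3 (1.79 log units; beyond the scatter) both beyond the scatter. Compound 4 `CCCN1CC[C@H](NC(=O)C[C@@H]2C(=O)NC=CN2S(=O)(=O)c2ccc(C)cc2)C(C)(C)C1` differs from compound 3 by ethyl in place of hydrogen on a saturated chain carbon bound to an amine nitrogen in a ring. For the measured compounds named here, every measured step, including a 7.8-fold higher number from compound 1 to compound 2 (0.89 log units; beyond the scatter), concerns the group on the amide-type nitrogen, so no measured step bears on this change at the ring amine. Without such precedent, the expected step in this assay is none beyond the scatter, a 1.4-fold higher number from compound 3 to compound 4 (0.15 log units; within the scatter). Compound 4 is therefore estimated at 0.6 nM, within a range of 0.15 nM to 2.5 nM.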

Compound 4, half-maximal inhibitory concentration: 0.51 nM
Beside the measured number, compound 4's estimate is 1.2-fold (0.07 log units) above it, and the stated range covers the measured number.
By their numbers in this assay, from the lowest: compounds 3 and 4 (each within the scatter of the next); then compound 1; then compound 2.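

Read as methyl to propyl, the difference between these two compounds gives a 1.2-fold higher number from compound 3 to compound 4 (0.08 log units; within the scatter) in this assay and so leaves the two values within the scatter of each other. For the compounds shown here, this is the first measured step at this place, on a saturated chain carbon bound to an amine nitrogen in a ring, and it shows that the propyl chain is accepted there as well as the methyl group. No evidence is available to account for this result. Going by these compounds, whether a benzyl group or a chain ending in a carboxylic acid would be accepted at this place remains open.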